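The source may hold more compounds than are shown below. What is called first, only, known or untested is meant among the compounds shown, and "the series" means these compounds.

Working notes on the series. Going by the values given here, in a functional assay on A549 cells (Homo sapiens) for inhibition, read by sulforhodamine B assay, with a stated time of 72 h (on this read-out lower numbers stand for stronger inhibition and higher numbers for weaker inhibition), compound 1 `C#Cc1cccc(Nc2ncnc3cc(OCCCCn4ccnc4[N+](=O)[O-])c(OC)cc23)c1` gives 1080 nM and compound 2 `C#Cc1cccc(Nc2ncnc3cc(OCCCCCn4ccnc4[N+](=O)[O-])c(OC)cc23)c1` gives 180 nM, the lower of the only two numbers so far. Compound 3 `C#Cc1cccc(Nc2ncnc3cc(OCCOCCn4ccnc4[N+](=O)[O-])c(OC)cc23)c1` has not yet been measured. The change from compound 2 is 2-(2-nitro-1H-imidazol-1-yl)ethoxy in place of 3-(2-nitro-1H-imidazol-1-yl)propyl on a saturated chain carbon, two bonds along the chain from an oxygen on an aromatic ring, and it sits on a saturated chain carbon, two bonds along the chain from an oxygen on an aromatic ring.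

Among the compounds with values here, only one measured step bears on this: a 6.0-fold lower number from compound 1 to compound 2 (0.78 log units; beyond the scatter). That edit also falls on the chain carrying the 2-nitro-1H-imidazol-1-yl group, so compound 2 shows that this assay can respond to chain changes. It is a different kind of edit, however, and gives only a rough guide to size. Within the data shown here, no measured pair shows the swap made in compound 3, so the direction is a tentative judgement, with a small rise in the number expected. The expected change is a 1.7-fold higher number from compound 2 to compound 3 (0.22 log units; within the scatter). For compound 3 the estimated value is 300 nM, with an expected range of 110 nM to 850 nM.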

Compound 3, half-maximal inhibitory concentration: 6430 nM
Estimate against measurement, compound 3: 21-fold (1.33 log units) below; measured number above the stated range.
By their numbers in this assay, from the lowest: compound 2; then compound 1; then compound 3.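

In this assay, the swap of 3-(2-nitro-1H-imidazol-1-yl)propyl for 2-(2-nitro-1H-imidazol-1-yl)ethoxy gives a 36-fold higher number from compound 2 to compound 3 (1.55 log units; beyond the scatter), which shows that the chain's make-up matters at this position as well as its length: both groups have 11 heavy atoms, and the entering group differs in holding 5 carbon and 3 oxygen against 6 carbon and 2 oxygen. The second new step, a 6.0-fold higher number from compound 1 to compound 3 (0.77 log units; beyond the scatter), shows that the oxygen-containing chain also gives a higher number than the shorter all-carbon chain, so among these three compounds the all-carbon chains give the lower numbers. No measurement shown here accounts for the size of either step.

The three compounds do not separate the presence of the chain oxygen from its location, and an amine nitrogen or a sulfur atom at the same chain place would test whether the rise is specific to oxygen. A longer all-carbon chain would show whether the fall in the number from compound 1 to compound 2 continues beyond the 3-(2-nitro-1H-imidazol-1-yl)propyl group.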